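A few compounds are considered here, and "the series" means these few. Any claim that something is new, unique, unknown or untested is made for them only; others in the source may bear on it.

Three compounds that share one core and differ only in the saturated chain bound to the sulfonyl sulfur have been measured in a functional assay, read by fluorescence and spectrophotometry, with a stated time of 1 h; a higher number here means that more compound is needed for the effect, a lower number that less compound is needed. Compound 1 `CCCCCCCCCCS(=O)(=O)/C=C/c1ccc(O)c(O)c1` gives 6800 nM, compound 2 `O=S(=O)(/C=C/c1ccc(O)c(O)c1)CC1CCCCC1` gives 7500 nM, and compound 3 `CCCCCCCCS(=O)(=O)/C=C/c1ccc(O)c(O)c1` gives 6400 nM. On the bare numbers compound 3 stands at the low end of the three, but both gaps to it sit within the scatter: a 1.1-fold lower number from compound 1 to compound 3 (0.03 log units; within the scatter), and a 1.2-fold lower number from compound 2 to compound 3 (0.07 log units; within the scatter). So far, neither the length nor the shape of the chain has moved the read-out beyond what repeated measurements would show on their own.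

Compound 4 `CCCCCS(=O)(=O)/C=C/c1ccc(O)c(O)c1` has not yet been measured. It differs from compound 3 in one place: hydrogen in place of propyl on a saturated chain carbon, five bonds along the chain from a sulfonyl sulfur. The step that bears most directly on this change is the earlier chain shortening, a 1.1-fold lower number from compound 1 to compound 3 (0.03 log units; within the scatter). The change to compound 4 removes somewhat more of the chain than that earlier step did, and no chain this short has been tested, so the evidence at hand supports only a small step, if any. The expected step is a 1.1-fold higher number from compound 3 to compound 4 (0.04 log units; within the scatter). Compound 4 is therefore estimated at 7000 nM, with a range from 3500 nM to 14000 nM.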

Compound 4, half-maximal effective concentration: 8100 nM
Compound 4: middle estimate off by 1.2-fold (0.06 log units), on the low side; low and high end bracket the measured number.
By their numbers in this assay, from the lowest: compounds 3, 1, 2 and 4 (each within the scatter of the next).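

In this assay, hydrogen in place of propyl on a saturated chain carbon, five bonds along the chain from a sulfonyl sulfur, gives a 1.3-fold higher number from compound 3 to compound 4 (0.10 log units; within the scatter) and so leaves the read-out level even with the shortest chain among these compounds. The larger cut at the same place, hydrogen in place of pentyl, gives a 1.2-fold higher number from compound 1 to compound 4 (0.08 log units; within the scatter) as its step, and an open chain in place of the ring gives a 1.1-fold higher number from compound 2 to compound 4 (0.03 log units; within the scatter) as its step, so neither a much shorter chain nor the loss of the ring separates compound 4 from the others. Nothing measured here explains why these chains read alike.

The compounds shown leave open how far the chain can be cut before the number moves beyond the scatter, as a methyl or ethyl group in its place might show. They also leave open whether a chain ending in an amine or a carboxylic acid would read differently from these plain saturated chains, and whether a change on the shared core itself would matter more than any change in the chain.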